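The source may hold more compounds than are shown below. What is called first, only, known or untested is meant among the compounds shown, and "the series" means these compounds.

Compound 1, `Cc1cc(=O)n(-c2ccc(F)cc2)nc1C(=O)Nc1ccc(Oc2ncnc3[nH]ccc23)cc1`, was tested in a functional assay on PC-3 cells (Homo sapiens) for cytotoxicity, read by MTT assay, with a stated time of 72 h; a higher number here means a weaker inhibitor, a lower number a stronger inhibitor. Compound 1 gives > 60000 nM there, which is a limit of the assay rather than a measured number, so its true value is not pinned down. Among the compounds with values here, compound 1 is the one compound resting at the limit of > 60000 nM in this assay, at which 1 of the 3 values shown sits. Two compounds that differ from it in the group on the aromatic nitrogen were measured as well. Compound 2, `Cc1cc(=O)n(-c2ccc(Br)cc2F)nc1C(=O)Nc1ccc(Oc2ncnc3[nH]ccc23)cc1`, gives 2730 nM in this assay, a change of an at least 21-fold lower number from compound 1 to compound 2 (1.34 log units; beyond the scatter). Compound 3, `Cc1cc(=O)n(-c2cccc(C(F)(F)F)c2)nc1C(=O)Nc1ccc(Oc2ncnc3[nH]ccc23)cc1`, gives 3460 nM in this assay, a change of an at least 17-fold lower number from compound 1 to compound 3 (1.23 log units; beyond the scatter). Between these two, a 1.3-fold higher number from compound 2 to compound 3 (0.10 log units; within the scatter), so they cannot be ordered against each other. Both steps show that a change on the aromatic nitrogen can move compound 1 off the limit.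

Compound 4, `Cc1cc(=O)n(-c2ccc(F)cc2)nc1C(=O)Nc1ccc(Oc2ncnc3[nH]ccc23)c(F)c1`, differs from compound 1 elsewhere: fluoro in place of hydrogen on an aromatic carbon. Within the data shown here, no measured step touches that ring, so none bears directly on this change. With compound 1 at the limit, a single added fluorine offers no ground to expect a departure from it, and the step of an at least 1.2-fold lower number from compound 1 to compound 4 (0.07 log units; that floor lies within the scatter) is expected to stay within the scatter. Compound 4 is therefore estimated at 50000 nM in this assay, within a range of 15000 nM to 150000 nM, with a fair chance that again only a limit is reported.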

Compound 4, half-maximal inhibitory concentration: 17300 nM
Compound 4: the middle estimate sits 2.9-fold (0.46 log units) above what was measured; the measured number falls inside the stated range.
By their numbers in this assay, from the lowest: compounds 2 and 3 (each within the scatter of the next); then compound 4. At a limit, above all of these: compound 1.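

The earlier compounds shown here moved off the limit only through the group on the aromatic nitrogen, whereas compound 4 keeps the 4-fluorophenyl group of compound 1 and changes a different part of the molecule. In this assay, a single fluoro on an aromatic carbon, ortho to a large group and meta to a large group, gives an at least 3.4-fold lower number from compound 1 to compound 4 (0.54 log units; beyond the scatter), so a change of just one heavy atom at this position is enough to produce a step beyond the scatter. The size of that step remains a floor, and the true gap may be larger, as the value for compound 1 is a limit and not a number: the limit of > 60000 nM in this assay, at which 1 of the 4 values shown sits.

The compounds shown leave open whether fluoro is special at this carbon or whether chlorine, a methyl group or an amine in the same place would give a similar step. They also leave open whether fluoro here would lower the number further when combined with the 4-bromo-2-fluorophenyl or 3-(trifluoromethyl)phenyl group on the aromatic nitrogen, as it appears here only with 4-fluorophenyl.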